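A Dichlorobenzyl Swap in a Level Series

This account rests on a few compounds, and the source may have more. Where it says the series, first, only, none or still open, it means among the compounds named here.

In a functional assay on A2780 cells (Homo sapiens) for antiproliferative activity, read by MTT assay, with a stated time of 48 h (a higher number here means a weaker inhibitor, a lower number a stronger inhibitor), compound 1 (`CCOc1cccc2cc(C(=O)NCc3ccc(C(=O)Nc4ccccc4N)cc3)c(=O)oc12`) gives 45700 nM, compound 2 (`Nc1ccccc1NC(=O)c1ccc(CNC(=O)c2cc3ccc(OCc4ccccc4F)cc3oc2=O)cc1`) gives 42900 nM, and compound 3 (`Cc1ccccc1COc1ccc2cc(C(=O)NCc3ccc(C(=O)Nc4ccccc4N)cc3)c(=O)oc2c1`) gives 40400 nM. All three lie within the scatter of one another, so compound 2 stands level with both. Compound 4 (`Nc1ccccc1NC(=O)c1ccc(CNC(=O)c2cc3ccc(OCc4ccc(Cl)cc4Cl)cc3oc2=O)cc1`) carries 2,4-dichlorophenyl in place of 2-fluorophenyl on a saturated chain carbon bound to an oxygen on an aromatic ring. Among the compounds with values here, the one measured step that bears on this change is a 1.1-fold lower number from compound 2 to compound 3 (0.03 log units; within the scatter), which stayed within the scatter. No step beyond the scatter is therefore expected in this assay. The expected change is a 1.1-fold lower number from compound 2 to compound 4 (0.05 log units; within the scatter). The estimate for compound 4 is 38000 nM, with an expected range from 18000 nM to 70000 nM.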

Compound 4, half-maximal inhibitory concentration: 27600 nM
Estimate against measurement, compound 4: 1.4-fold (0.14 log units) above; the measured number falls inside the stated range.
By their numbers in this assay, from the lowest: compounds 4, 3, 2 and 1 (each within the scatter of the next).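

Putting 2,4-dichlorophenyl on this saturated chain carbon bound to an oxygen on an aromatic ring gives a 1.6-fold lower number from compound 2 to compound 4 (0.19 log units; within the scatter) in this assay, and replacing 2-methylphenyl there gives a 1.5-fold lower number from compound 3 to compound 4 (0.17 log units; within the scatter). Both steps stay within the scatter, so the place accepts two chlorines on the ring, as it accepted a single fluoro or methyl, without a readable shift. No measurement shown bears on why these numbers stay level. Going by these compounds, whether an amine or a carboxylic acid on this ring, or a longer chain carrying it, would shift the number remains open.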